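Sulfonyl amide variant of compound 3

This account rests on a few compounds, and the source may have more. Where it says the series, first, only, none or still open, it means among the compounds named here.

The three amides measured so far share one core. Compound 1 `O=C(Nc1ccc(Cl)c(-c2nnc3c(Cl)cccn23)c1)c1ccc(Cl)cc1` carries a 4-chlorophenyl on the carbonyl carbon, compound 2 `O=C(Nc1ccc(Cl)c(-c2nnc3c(Cl)cccn23)c1)c1ccc(Cl)cc1Cl` a 2,4-dichlorophenyl, and compound 3 `O=C(Nc1ccc(Cl)c(-c2nnc3c(Cl)cccn23)c1)c1c(F)cccc1Cl` a 2-chloro-6-fluorophenyl. In a functional assay on MDA-MB-231 cells (Homo sapiens) for antiproliferative activity, read by MTT assay, with stated times of 72 h and 4 h (on this read-out higher numbers stand for weaker inhibition and lower numbers for stronger inhibition), compound 1 gives only a limit, > 100000 nM. Compound 2 likewise gives only a limit, > 100000 nM. Compound 3 also reaches only a limit, > 100000 nM, so all three sit at the limit of > 100000 nM in this assay, at which 3 of the 3 values shown sit. The steps a step that the two limits leave unreadable from compound 1 to compound 2, a step that the two limits leave unreadable from compound 1 to compound 3 and a step that the two limits leave unreadable from compound 2 to compound 3 are thus unreadable. Compound 4 `CS(=O)(=O)c1cccc(C(=O)Nc2ccc(Cl)c(-c3nnc4c(Cl)cccn34)c2)c1` differs from compound 3 by 3-(methylsulfonyl)phenyl in place of 2-chloro-6-fluorophenyl on a carbonyl carbon. Among the compounds with values here, no measured step reads, so no direction is expected in this assay beyond the scatter. Compound 4 is estimated at 100000 nM, between 30000 nM and 300000 nM, with the expected step of a number no higher from compound 3 to compound 4 (the limit leaves the size open) and a further limit likely.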

Compound 4, half-maximal inhibitory concentration: > 100000 nM
Compound 4: only a limit was reported; the forecaster's own chance of this, stated with the estimate: 75%; the middle value lies on the limit itself.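

Within the data shown here, no step to compound 4 from compound 1, compound 2 or compound 3 can be read; all four values are limits. In this assay the compounds shown leave open which group on the carbonyl carbon, if any, would give a number rather than a limit.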